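The source may report more compounds than this note shows. Statements on the series, on what has been measured and on what is new or still open speak of the compounds shown alone.

Compound 1 `N#CC1=C(/N=C/Nc2ccc([N+](=O)[O-])cc2)N(c2ccccc2)C(=O)N2CCCCC(N3CCCC3)C12` was tested in a functional assay on the whole organism (strain albino) for inhibition, with Rattus norvegicus as the target, read by paw edema, with stated times of 1 h and 3 h, at a dose of 20 mmol/kg by the intraperitoneal route (a higher number here means a stronger effect of the compound at the dose given, a lower number a weaker effect), where compound 1 gives 85.6%. Among the three measured compounds this is the second highest number. Compound 3 `N#CC1=C(N)N(c2ccccc2)C(=O)N2CCCCC(N3CCCC3)C12`, which carries a plain amino group on the same ring carbon, gives 90.1%, and the change to it was a number 4.5 percentage points higher from compound 1 to compound 3 (within the scatter). Compound 2 `N#CC1=C(NCN2CCCCC2)N(c2ccccc2)C(=O)N2CCCCC(N3CCCC3)C12`, which bears a (piperidin-1-yl)methyl on the amine nitrogen, gives 42.1%, so that a number 43.5 percentage points lower from compound 1 to compound 2 (beyond the scatter). Compound 4 `N#CC1=C(NCC(=O)N2CCCCC2)N(c2ccccc2)C(=O)N2CCCCC(N3CCCC3)C12` has not been measured. It differs from compound 1 in one place: a group of 10 heavy atoms (7 carbon, 2 nitrogen, 1 oxygen; one six-membered non-aromatic ring with 1 hetero atom) in place of a group of 12 heavy atoms (7 carbon, 3 nitrogen, 2 oxygen; one six-membered aromatic ring of carbon only), on a double-bonded ring carbon. The entering group, like the group in compound 2, holds a six-membered non-aromatic ring with one hetero atom on the amine nitrogen, so the step of a number 43.5 percentage points lower from compound 1 to compound 2 (beyond the scatter) is the closest guide, while a number 4.5 percentage points higher from compound 1 to compound 3 (within the scatter) shows that a small amino group alone stays within the scatter. A drop is therefore expected, though its size is uncertain: the estimated step is a number 30.6 percentage points lower from compound 1 to compound 4 (beyond the scatter), and compound 4 is expected to give 55%, within a range from 35% to 80%.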

Compound 4, a percentage reported as inhibition, in the whole organism at one dose (the size of the read-out at that dose, not a potency): 53.5%
Estimate against measurement, compound 4: 1.5 percentage points above; the measured number falls inside the stated range.
By their numbers in this assay, from the lowest: compound 2; then compound 4; then compounds 1 and 3 (each within the scatter of the next).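

In this assay, the second compound with a piperidine ring on the amine nitrogen also falls well short: a number 32.1 percentage points lower from compound 1 to compound 4 (beyond the scatter) and a number 36.6 percentage points lower from compound 3 to compound 4 (beyond the scatter). Size alone does not set the number, since the group that leaves compound 1 is the larger one, yet compound 1 stays with compound 3 at the top. Among these compounds, the carbonyl gives a first reading within this pair of piperidine compounds: with (piperidin-1-yl)carbonyl in place of piperidin-1-yl, there is a number 11.4 percentage points higher from compound 2 to compound 4 (beyond the scatter), a modest step that leaves compound 4 far from compound 3. Nothing here gives a measured reason for these differences.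

From the compounds shown here alone, whether the loss follows the piperidine ring or the chain that carries it stays open. A morpholine ring, a diethylamino group or a longer chain at this nitrogen could help separate the two.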